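Inverting One Stereocentre of Compound 3

The source may hold more compounds than are shown below. What is called first, only, known or untested is meant among the compounds shown, and "the series" means these compounds.

In an ADME assay on CV-1 cells (Chlorocebus aethiops) for cytotoxicity, read by MTT assay (on this read-out lower numbers stand for stronger inhibition and higher numbers for weaker inhibition), compound 1 `CC(=O)CC/C=C(\C)C[C@@H]1C=C(CCC=C(C)C)C(=O)O1` gives > 100000 nM as a limit of the assay and not as a number. Compound 2 `CC(C)=CCCC1=C[C@@H](C/C(C)=C/CC/C(C)=C/CC2=CC(=O)C=C(C)C2=O)OC1=O` gives 50000 nM and compound 3 `CC(C)=CCC/C(=C/CC/C(C)=C/CC[C@]1(C)C=Cc2cc(O)cc(C)c2O1)C(=O)O` gives 45000 nM as a number within the scatter of compound 2. Compound 4 `CC(C)=CCC/C(=C/CC/C(C)=C/CC[C@@]1(C)C=Cc2cc(O)cc(C)c2O1)C(=O)O` has the same atoms and bonds as compound 3 and differs only in configuration as drawn: the two compounds have the same atoms and bonds and differ only in configuration as drawn: 1 of 3 stereo elements differ; a stereocentre at a saturated ring carbon is drawn R in compound 3 and S in compound 4 and a stereocentre at a saturated ring carbon is drawn R in compound 3 and S in compound 4. For the measured compounds named here, no measured pair shows what such a change does, so no step beyond the scatter is expected in this assay in either direction. The expected move is a 1.1-fold higher number from compound 3 to compound 4 (0.05 log units; within the scatter) and stays inside the scatter. For compound 4 the estimated value is 50000 nM with an expected range of 25000 nM to 100000 nM around it.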

Compound 4, half-maximal inhibitory concentration: 56000 nM
The estimate for compound 4 lay 1.1-fold (0.05 log units) below the measured number, and the stated range covers the measured number.
By their numbers in this assay, from the lowest: compounds 3, 2 and 4 (each within the scatter of the next). At a limit, above all of these: compound 1.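

In this assay inverting the stereocentre at the saturated ring carbon gives a 1.2-fold higher number from compound 3 to compound 4 (0.09 log units; within the scatter) and so leaves the number unchanged within the scatter. The earlier compounds shown here offered no pair that differed in one place, whereas this pair reads that centre alone: the fact that compounds 3 and 4 differ only in the configuration as drawn. Configuration at this carbon therefore shows no measurable effect on the number in this assay.

On these data alone, both compounds keep the carboxylic acid, so what a methyl ester or an amine in its place would do remains open. As far as these compounds go, whether the configuration matters equally with such a group is also open.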